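The source may report more compounds than this note shows. Statements on the series, on what has been measured and on what is new or still open speak of the compounds shown alone.

Measured in a functional assay on MCF7 cells (Homo sapiens) for antiproliferative activity, read by luminescence, with a stated time of 24 h; on this read-out lower numbers stand for stronger inhibition and higher numbers for weaker inhibition
- compound 1 `Cc1cc(C)c2c(c1C)OC(C)(COc1ccc(/C=C3\SC(=O)NC3=O)cc1)CC2` gives 12500 nM
- compound 2 `Cc1c(C)c2c(c(C)c1OC(=O)CCCC[C@@H]1SC[C@@H]3NC(=O)N[C@@H]31)CCC(C)(COc1ccc(CC3SC(=O)NC3=O)cc1)O2` gives 15900 nM
- compound 3 `CC(=O)NCCNC(=O)CCC(=O)Oc1c(C)c(C)c2c(c1C)CCC(C)(COc1ccc(/C=C3\SC(=O)NC3=O)cc1)O2` gives > 50000 nM (a limit, not a number)

For the measured compounds named here, compound 1 and compound 2 hold the only two numbers and sit within the scatter of each other. The entry for compound 3 is a limit and not a number.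

The next entry is compound 4 `Cc1c(C)c2c(c(C)c1O)CCC(C)(COc1ccc(/C=C3\SC(=O)NC3=O)cc1)O2`, which differs from compound 1 by hydroxy in place of hydrogen on an aromatic carbon. Going by the values given here, no measured pair isolates this change, so the expectation is indirect. No step beyond the scatter is expected, in either direction: compound 2 carries an ester on that carbon and still gives (15900 nM) within the scatter of compound 1. Compound 3 also carries an ester there and goes against this reading. The estimate means a 1.1-fold lower number from compound 1 to compound 4 (0.06 log units; within the scatter) and this expected step stays within the scatter. For compound 4 the estimated value is 11000 nM within an expected range (5000 nM to 25000 nM).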

Compound 4, half-maximal inhibitory concentration: 29700 nM
Beside the measured number, compound 4's estimate is 2.7-fold (0.43 log units) below it, and the stated range ends below it.
By their numbers in this assay, from the lowest: compounds 1, 2 and 4 (each within the scatter of the next, the first and the last beyond it). At a limit, above all of these: compound 3.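

For the compounds shown here, at the aromatic carbon ortho to two methyl groups, hydroxy in place of hydrogen gives a 2.4-fold higher number from compound 1 to compound 4 (0.38 log units; beyond the scatter) in this assay, and this is the first step that isolates a single change. The step is modest, but it shows that this position is not indifferent to substitution, which compound 2 and compound 3 could not show because each differs from compound 1 in more than one place. Compound 3, which carries an ester on that carbon, stands at a limit and not at a number: the limit of > 50000 nM in this assay, at which 1 of the 4 values shown sits.

The cause of the step cannot be read from these compounds. On these data alone, whether it belongs to hydroxy alone remains open, and a methoxy group, an amine or a carboxylic acid on the same carbon would help separate that from a general effect of substitution there.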